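The compounds below may be only part of what the source reports. "The series", "measured", "known", "first", "only" and "open" are said of these compounds alone.

Series notes. Compound 1 `c1ccc2c(c1)CN[C@@H](CN(CCCCNC1CCOCC1)[C@H]1CCCc3cccnc31)C2` gives 29.4 nM in a functional assay on cells for antagonist activity at C-X-C chemokine receptor type 4 (Homo sapiens), read by fluorescence and calcium flux, with stated times of 25 min and 90 s; a lower number here means a stronger inhibitor, a higher number a weaker inhibitor; compound 2 `c1ccc2c(c1)CN[C@@H](CN(CCCCNC1CCNCC1)[C@H]1CCCc3cccnc31)C2` gives 63.4 nM; compound 3 `CC(C)(CCN(C[C@H]1Cc2ccccc2CN1)[C@H]1CCCc2cccnc21)CNCC1CCOCC1` gives 43.8 nM. Compound 3 stands second highest of the three numbers, within the scatter of both neighbours: a 1.5-fold higher number from compound 1 to compound 3 (0.17 log units; within the scatter) and a 1.4-fold lower number from compound 2 to compound 3 (0.16 log units; within the scatter). Compound 4 `CC1(C)CCC(NCC(C)(C)CCN(C[C@H]2Cc3ccccc3CN2)[C@H]2CCCc3cccnc32)CC1` differs from compound 3 by 4,4-dimethylcyclohexyl in place of (oxan-4-yl)methyl on an amine nitrogen. Within the data shown here, the only measured step that alters just the ring on that terminal amine is a 2.2-fold higher number from compound 1 to compound 2 (0.33 log units; beyond the scatter), a modest shift; no measured pair makes a change of the present kind, so direct guidance is thin. On that basis the step is expected to stay small, direction uncertain, a 1.0-fold higher number from compound 3 to compound 4 (0.01 log units; within the scatter). Compound 4 is therefore estimated at 45 nM, with a range of 15 nM to 140 nM.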

Compound 4, half-maximal inhibitory concentration: 541 nM
Beside the measured number, compound 4's estimate is 12-fold (1.08 log units) below it, and the stated range ends below it.
By their numbers in this assay, from the lowest: compounds 1, 3 and 2 (each within the scatter of the next, the first and the last beyond it); then compound 4.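

Among these compounds, the group on this amine nitrogen is less tolerant than the earlier compounds indicated: in this assay there is a 12-fold higher number from compound 3 to compound 4 (1.09 log units; beyond the scatter), well beyond the earlier 2.2-fold higher number from compound 1 to compound 2 (0.33 log units; beyond the scatter). The change from (oxan-4-yl)methyl to 4,4-dimethylcyclohexyl alters the ring atoms, the ring substitution and the link to the nitrogen at once, and these compounds do not separate those parts. Nothing on hand accounts for the loss. Still open, as far as these compounds go, is whether a plain cyclohexyl or a cyclohexylmethyl group on this nitrogen would stay close to compound 3 or fall with compound 4.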